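A few compounds are considered here, and "the series" means these few. Any claim that something is new, unique, unknown or untested is made for them only; others in the source may bear on it.

Compound 1 `COc1nc2ccc(Br)cc2cc1C(c1ccccc1)n1cc(C2CC2)nn1` gives 22.6% in an ADME assay on PC-3 cells (Homo sapiens) for cytotoxicity, read by sulforhodamine B assay, with a stated time of 48 h, tested at 10 uM; on this read-out lower numbers stand for less inhibition and higher numbers for more inhibition at the one concentration tested (going by the name of the read-out). Compound 2 `COc1nc2ccc(Br)cc2cc1C(c1ccccc1)n1cc(-c2ccccc2F)nn1` gives 13.4% in this assay, and compound 3 `CCCCc1cn(C(c2ccccc2)c2cc3cc(Br)ccc3nc2OC)nn1` gives 5.54% in this assay, the lowest of the three numbers, although its gap to compound 2 lies within the scatter. The steps of a number 17.1 percentage points lower from compound 1 to compound 3 (beyond the scatter) and a number 7.9 percentage points lower from compound 2 to compound 3 (within the scatter) both run downward toward compound 3. Compound 4 `CCCCCCCCc1cn(C(c2ccccc2)c2cc3cc(Br)ccc3nc2OC)nn1` differs from compound 3 by butyl in place of hydrogen on a saturated chain carbon, four bonds along the chain from an aromatic carbon. For the measured compounds named here, no measured step lengthens a chain in this way; the step of a number 17.1 percentage points lower from compound 1 to compound 3 (beyond the scatter) concerns a chain replacing a ring, so it bears only loosely. Compound 3 already sits low on the read-out, and the expected step of a number 2.5 percentage points higher from compound 3 to compound 4 (within the scatter) is none beyond the scatter. Compound 4 is estimated at 8%, with a range from 0% to 25% in this assay.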

Compound 4, a percentage reported as inhibition, at one concentration (the size of the read-out at that concentration, not a potency): 2.27%
Compound 4: the middle estimate sits 5.7 percentage points above what was measured; low and high end bracket the measured number.
By their numbers in this assay, from the lowest: compounds 4, 3, 2 and 1 (each within the scatter of the next, the first and the last beyond it).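

Butyl in place of hydrogen on a saturated chain carbon, four bonds along the chain from an aromatic carbon, gives a number 3.3 percentage points lower from compound 3 to compound 4 (within the scatter) in this assay, so this lengthening of the chain does not separate the two compounds. Octyl on the aromatic carbon gives a number 11.1 percentage points lower from compound 2 to compound 4 (beyond the scatter) against 2-fluorophenyl and a number 20.3 percentage points lower from compound 1 to compound 4 (beyond the scatter) against cyclopropyl, both steps clearing the scatter. No evidence accounts for these numbers.

The compounds shown leave open how a chain longer than octyl would read. As far as these compounds go, an amine or a carboxylic acid at the chain end also remains open.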